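Urea in Place of Thiourea on the Hydroxybenzyl Core

The source may hold more compounds than are shown below. What is called first, only, known or untested is meant among the compounds shown, and "the series" means these compounds.

The measured compounds: compound 1 `O=[N+]([O-])c1cccc(NC(=S)NCCNS(=O)(=O)c2ccc(-c3ccccc3OCc3ccccc3)s2)c1` gives 12800 nM in a functional assay on HeLa cells (Homo sapiens) for inhibition, read by CCK-8 assay, with a stated time of 48 h; on this read-out higher numbers stand for weaker inhibition and lower numbers for stronger inhibition. Compound 2 `Cc1cc(C)cc(NC(=O)NCCNS(=O)(=O)c2ccc(-c3ccccc3OCc3ccccc3)s2)c1` gives only a limit of the assay, > 50000 nM. Compound 3 `O=[N+]([O-])c1cccc(NC(=S)NCCNS(=O)(=O)c2ccc(-c3ccccc3OCc3cccc(O)c3)s2)c1` gives 11100 nM.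

Compound 3 differs from compound 1 by hydroxy in place of hydrogen on an aromatic carbon, and the step of a 1.2-fold lower number from compound 1 to compound 3 (0.06 log units; within the scatter). Compound 2 differs from compound 1 by a group of 11 heavy atoms (9 carbon, 1 nitrogen, 1 oxygen; one six-membered aromatic ring of carbon only) in place of a group of 12 heavy atoms (7 carbon, 2 nitrogen, 2 oxygen, 1 sulfur; one six-membered aromatic ring of carbon only), on an amine nitrogen, and the step of an at least 3.9-fold higher number from compound 1 to compound 2 (0.59 log units; beyond the scatter); this value sits at the limit of > 50000 nM in this assay, at which 1 of the 3 values shown sits, so the true size of that step is not known.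

Compound 4 `Cc1cc(C)cc(NC(=O)NCCNS(=O)(=O)c2ccc(-c3ccccc3OCc3cccc(O)c3)s2)c1` differs from compound 3 by a group of 11 heavy atoms (9 carbon, 1 nitrogen, 1 oxygen; one six-membered aromatic ring of carbon only) in place of a group of 12 heavy atoms (7 carbon, 2 nitrogen, 2 oxygen, 1 sulfur; one six-membered aromatic ring of carbon only), on an amine nitrogen. Going by the values given here, this is the same kind of change as the one from compound 1 to compound 2, made on a core that differs by hydroxy in place of hydrogen on an aromatic carbon; the place lines of the two changes read the same. Since the change from compound 1 to compound 2 pushed the value to a limit, compound 4 is expected to show a step of a 5.4-fold higher number from compound 3 to compound 4 (0.73 log units; beyond the scatter), most likely again reaching a limit. The estimate for compound 4 is 60000 nM, expected to lie between 25000 nM and 150000 nM.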

Compound 4, half-maximal inhibitory concentration: > 20000 nM
Compound 4: only a limit was reported; the forecaster's own chance of this, stated with the estimate: 70%; the middle value does not contradict the limit.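

In this assay compound 4 gives > 20000 nM, which is a limit of the assay and not a number. With (3,5-dimethylphenyl)carbamoyl entering on the amine nitrogen of the hydroxy-bearing core, the result is an at least 1.8-fold higher number from compound 3 to compound 4 (0.25 log units; that floor lies within the scatter), so this floor alone does not establish a step beyond the scatter on this core. The step linking compound 2 and compound 4 cannot be read, and the result is consistent with the change carrying over to the second core but fixes its size on neither: the same change on two cores in this assay, an at least 3.9-fold higher number (0.59 log units; beyond the scatter) from compound 1 to compound 2 and an at least 1.8-fold higher number (0.25 log units; that floor lies within the scatter) from compound 3 to compound 4; the limit leaves it open whether they differ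

The compounds shown leave open how much of the change comes from the carbonyl in place of the thiocarbonyl and how much from the substituents on the aromatic ring, since the two are altered together. They also leave open whether the change would behave the same way on a core carrying an amine or a carboxylic acid in place of the hydroxy.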